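The compounds below may be only part of what the source reports. "The series", "measured", "known", "first", "only" and "open" are said of these compounds alone.

Of the compounds shown here, three with a shared core have been measured in a physicochemical assay for lipophilicity, at pH 7.4; on this read-out lower numbers stand for lower lipophilicity and higher numbers for higher lipophilicity. Compound 1 (`COc1ccc(NC(=O)[C@H]2CCCN2C(=O)C2(c3cccc(Cl)c3)CCCC2)nc1`) gives 6.8, compound 2 (`O=C(Nc1ccc2[nH]c(=O)[nH]c2c1)[C@H]1CCCN1C(=O)C1(c2cccc(Cl)c2)CCCC1`) gives 4.4, and compound 3 (`O=C1Cc2cc(NC(=O)[C@H]3CCCN3C(=O)C3(c4cccc(Cl)c4)CCCC3)ccc2N1`) gives 5, which makes compound 3 the second highest of the three. Compound 4 (`O=C(Nc1cnc2[nH]ncc2c1)[C@H]1CCCN1C(=O)C1(c2cccc(Cl)c2)CCCC1`) has not yet been measured. It differs from compound 3 in one place, on an amide-type nitrogen: a group of 9 heavy atoms (6 carbon, 3 nitrogen; one five-membered aromatic ring with 2 hetero atoms, one six-membered aromatic ring with 1 hetero atom) in place of a group of 10 heavy atoms (8 carbon, 1 nitrogen, 1 oxygen; one five-membered non-aromatic ring with 1 hetero atom, one six-membered aromatic ring of carbon only), on an amide-type nitrogen.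

Among the measured compounds shown here, three measured steps bear on this change, though none makes this exact exchange. Two are large, a number 2.40 log units lower from compound 1 to compound 2 (beyond the scatter) and a number 1.80 log units lower from compound 1 to compound 3 (beyond the scatter), and one is modest, a number 0.60 log units higher from compound 2 to compound 3 (beyond the scatter). The entering group has a six-membered aromatic ring with 1 hetero atom, a ring type also found in the group of compound 1, which stands at 6.8. It also has a five-membered aromatic ring with 2 hetero atoms, a ring type also found in the group of compound 2, which stands at 4.4. A result inside that span is therefore expected, nearer the lower end, with a modest step upward in this assay. The expected move is a number 0.40 log units higher from compound 3 to compound 4 (beyond the scatter). Compound 4 is estimated at 5.4, with an expected range from 4.7 to 6.1.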

Compound 4, distribution coefficient: 4.9
Beside the measured number, compound 4's estimate is 0.50 log units above it; measured number inside the range.
By their numbers in this assay, from the lowest: compound 2; then compounds 4 and 3 (each within the scatter of the next); then compound 1.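

In this assay, the step on the amide-type nitrogen reads a number 0.10 log units lower from compound 3 to compound 4 (within the scatter), so a group with a six-membered aromatic ring with 1 hetero atom and a five-membered aromatic ring with 2 hetero atoms cannot be told apart from the group of compound 3, although it shares a ring type with the group of compound 1. That ring type did not bring the number close to that of compound 1, as the step reads a number 1.90 log units lower from compound 1 to compound 4 (beyond the scatter), whereas the step of a number 0.50 log units higher from compound 2 to compound 4 (beyond the scatter) shows that with a five-membered aromatic ring with 2 hetero atoms in both groups, a six-membered aromatic ring with 1 hetero atom goes with a modest rise over a six-membered aromatic ring of carbon only. No measurement shown accounts for these steps.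

Compound 1 alone carries a group with a single ring, so the compounds shown cannot separate the contribution of the second ring from that of the other differences among these groups. They also leave open how this assay would respond on this nitrogen to a group bearing an amine or a carboxylic acid, or to a longer chain.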